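The compounds below may be only part of what the source reports. "The series", "measured", "known", "first", "only" and "open" are said of these compounds alone.

Measured so far:
- compound 1, `COc1cc(OC)c(OC)cc1/C=C/C(=O)c1ccc(C)cc1`: 33000 nM
- compound 2, `COc1cc(OC)c(-c2cc(=O)c3cc(O)ccc3o2)cc1OC`: > 150000 nM

Among the measured compounds shown here, compound 1 is the one compound here with a number in a functional assay on MCF7 cells (Homo sapiens) for inhibition, read by MTT assay, with a stated time of 72 h; on this read-out higher numbers stand for weaker inhibition and lower numbers for stronger inhibition: it gives 33000 nM. Compound 2 reaches only the limit of > 150000 nM in this assay, at which 1 of the 2 values shown sits, in this assay, a limit and not a number, so nothing can be said of the gap between compound 2 and compound 1 beyond the fact that one is a number and the other a limit.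

The unmeasured compound 3, `COc1cc(OC)c(OC)cc1/C=C/C(=O)c1ccc(F)cc1`, is reached from compound 1 by one change: fluoro in place of methyl on an aromatic carbon. For the measured compounds named here, no measured pair here shows a step of this kind, so the size of the step in this assay is not backed by any number. Given that, the expectation for the step from compound 1 to compound 3 is a 1.1-fold lower number from compound 1 to compound 3 (0.04 log units; within the scatter), which is meant as none beyond the usual scatter.

For compound 3 the value in this assay is therefore estimated at 30000 nM, with a range of 8000 nM to 120000 nM.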

Compound 3, half-maximal inhibitory concentration: 30000 nM
Compound 3: the middle estimate sits on the measured number at the digits printed; the range from low to high includes it.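

Among the compounds shown here, the first step that can be read in this assay is the change from 4-methylphenyl to 4-fluorophenyl, which gives a 1.1-fold lower number from compound 1 to compound 3 (0.04 log units; within the scatter). For the compounds shown here, at this place, on an aromatic carbon para to a large group, methyl and fluoro therefore cannot be told apart on this read-out, whereas the earlier compounds offered no pair differing in one place and so no measure of any change. No measured property among the compounds shown bears on this result.

Open, going by these compounds, is whether the position responds to any group at all: two substituents that read alike, each of a single heavy atom, say nothing about an amine, a carboxylic acid or a longer chain such as butyl at the same place. Also open, on these data alone, is whether the rest of the shared core would respond more strongly than this position, and whether fluoro in place of methyl would read the same on another core, since this step rests on a single pair in this assay.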